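The source may report more compounds than this note shows. Statements on the series, on what has been measured and on what is new or still open speak of the compounds shown alone.

Measured so far in an assay on isolated protein for inhibition of Ectonucleotide pyrophosphatase/phosphodiesterase family member 1 (Homo sapiens), tested at 10 uM; on this read-out lower numbers stand for less inhibition and higher numbers for more inhibition at the one concentration tested (going by the name of the read-out):
compound 1, `COc1ccc(NC(=O)CSc2nc3c(=O)n(C)c(=O)n(C)c3[nH]2)cc1OC`, gives 23%
compound 2, `COc1ccc(NC(=O)CSc2nc3ccc(OCC(F)(F)F)nc3[nH]2)cc1OC`, gives 61%
compound 3, `O=C(CSc1nc2cccnc2[nH]1)Nc1ccc(F)cc1`, gives 30%

Compound 3 stands second highest of the three numbers. Its nearest neighbour is compound 1, whose number lies lower but within the scatter, so the two cannot be ordered; its furthest is compound 2, whose number lies higher and beyond the scatter. Going by the values given here, no two measured compounds differ in one place only, so no single-change step is available as a yardstick.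

Compound 4, `O=C(CSc1nc2cccnc2[nH]1)Nc1ccc(Cl)cc1`, differs from compound 3 by chloro in place of fluoro on an aromatic carbon. A change of this kind has no measured parallel here. The step of a number 4 percentage points higher from compound 3 to compound 4 (within the scatter) is expected to remain within the scatter, with no direction called. Compound 4 is therefore estimated at 34% in this assay, with a range from 15% to 55%.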

Compound 4, a percentage reported as inhibition, at one concentration (the size of the read-out at that concentration, not a potency): 17%
For compound 4 the middle estimate is 17 percentage points above the measured one; measured number inside the range.
By their numbers in this assay, from the lowest: compounds 4, 1 and 3 (each within the scatter of the next, the first and the last beyond it); then compound 2.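

In this assay, chloro in place of fluoro on an aromatic carbon, para to a large group, gives a number 13 percentage points lower from compound 3 to compound 4 (beyond the scatter). Going by these compounds alone, this is the first single-change step, and it shows that this position responds to the exchange of one halogen for another, with the 4-fluorophenyl compound ahead of its 4-chlorophenyl partner. No measurement on this pair accounts for the step.

On these data alone, whether an amine, a carboxylic acid or a nitrile at this position would hold or raise the number remains open. Also open, as far as these compounds go, is whether the same exchange gives a similar step on the core of compound 2.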